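The compounds below may be only part of what the source reports. "The series", "measured", "known", "first", "only" and "open" are said of these compounds alone.

Measured in an ADME assay on HFF cells (Homo sapiens) for cytotoxicity, read by MTT assay, with a stated time of 72 h; on this read-out higher numbers stand for weaker inhibition and lower numbers for stronger inhibition:
compound 1 `Cc1ccc(S(=O)(=O)NCc2cn(C[C@H](O)[C@H]3OC(=O)C(OCc4ccccc4)=C3OCc3ccccc3)nn2)cc1`, 50 nM
compound 2 `O=C1O/C(=C\Cn2cc(-c3cc(F)cc(F)c3)nn2)C(OCc2ccccc2)=C1OCc1ccccc1`, > 100000 nM, a limit of the assay
compound 3 `COc1ccc(-c2cn(C[C@H](O)[C@H]3OC(=O)C(OCc4ccccc4)=C3OCc3ccccc3)nn2)cc1`, < 10 nM, a limit of the assay

Compound 3 stands at the limit of < 10 nM in this assay, at which 1 of the 3 values shown sits, so only a bound is known for it. Compound 2 stands at the limit of > 100000 nM in this assay, at which 1 of the 3 values shown sits. Compound 4 `CCCCCCCCCCc1cn(C[C@H](O)[C@H]2OC(=O)C(OCc3ccccc3)=C2OCc2ccccc2)nn1` differs from compound 3 by decyl in place of 4-methoxyphenyl on an aromatic carbon. Within the data shown here, the one step measured at the same aromatic carbon, an at least 5.0-fold lower number from compound 1 to compound 3 (0.69 log units; beyond the scatter), shows that this position bears a change with an at least modest effect; compound 2 differs in more than one place and gives no guidance. Among the measured compounds shown here, no measured pair compares a decyl with an aromatic group, so the direction is uncertain; a modest step upward from the bound is expected, an at least 2.5-fold higher number from compound 3 to compound 4 (0.39 log units; beyond the scatter). Compound 4 is estimated at 25 nM, within 5 nM to 150 nM.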

Compound 4, half-maximal inhibitory concentration: > 100000 nM
Compound 4 was reported as a limit; the forecaster's own chance of this, stated with the estimate: 25%; middle value at least 4000-fold (3.60 log units) away from the limit.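

In this assay, this aromatic carbon proves far more sensitive to change than the earlier step showed: decyl in place of 4-methoxyphenyl gives an at least 10000-fold higher number from compound 3 to compound 4 (4.00 log units; beyond the scatter). Nonyl in place of ((4-methylphenyl)sulfonyl)amino gives an at least 2000-fold higher number from compound 1 to compound 4 (3.30 log units; beyond the scatter), so the long alkyl chain gives the higher number against both earlier groups. Both steps are open-ended, as the decyl compound sits at a limit: the limit of > 100000 nM in this assay, at which 2 of the 4 values shown sit.

On these data alone, whether chain length or the loss of a ring drives the jump stays open. A butyl chain or a cyclohexyl group at this carbon would separate the two.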